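Inverting Two Ring Stereocentres of Compound 2

The source may hold more compounds than are shown below. What is called first, only, known or untested is meant among the compounds shown, and "the series" means these compounds.

Compound 1 (`CC(C)(C)[C@@H](O)C(=O)N1C[C@@H]2C[C@@H]2[C@H]1C(=O)NCc1cc(Cl)ccc1-n1cnnn1`) and compound 2 (`O=C(NCc1cc(Cl)ccc1-n1cnnn1)[C@@H]1C[C@H]2C[C@H]2N1C(=O)[C@H](O)c1ccccc1`) have both been measured in an ADME assay on the whole organism (strain Sprague-Dawley) for pharmacokinetics, with Rattus norvegicus as the target; on this read-out lower numbers stand for slow clearance and higher numbers for fast clearance. Compound 1 gives 26 mL/min/kg there and compound 2 gives 18 mL/min/kg there, which places compound 2 within the usual scatter of compound 1. Going by the values given here, the two differ in more than one place, so they provide no single-change step to draw on. Compound 3 (`O=C(NCc1cc(Cl)ccc1-n1cnnn1)[C@@H]1C[C@@H]2C[C@@H]2N1C(=O)[C@H](O)c1ccccc1`) has yet to be measured. It has the same atoms and bonds as compound 2 and differs only in configuration as drawn (the two compounds have the same atoms and bonds and differ only in configuration as drawn: 2 of 4 stereo elements differ; a stereocentre at a saturated ring carbon is drawn R in compound 2 and S in compound 3; a stereocentre at a saturated ring carbon is drawn R in compound 2 and S in compound 3), with two stereocentres at saturated ring carbons drawn S rather than R. The data give no direction for such a change, so the expected step of a 1.1-fold higher number from compound 2 to compound 3 (0.05 log units; within the scatter) is none beyond the scatter. In this assay the estimated value for compound 3 is 20 mL/min/kg with an expected range of 9 mL/min/kg to 45 mL/min/kg around that figure.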

Compound 3, clearance: 20 mL/min/kg
The estimate for compound 3 equals the measured number at the digits printed, within the range that was stated.
By their numbers in this assay, from the lowest: compounds 2, 3 and 1 (each within the scatter of the next).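

Going by these compounds alone, this pair gives the first step that can be read for a single kind of change, and in this assay inverting the two saturated ring carbons together yields a difference within the scatter (a 1.1-fold higher number from compound 2 to compound 3 (0.05 log units; within the scatter)). Compounds 1 and 2 could show nothing of this kind, as they differ in more than one place. For these two ring stereocentres, inverted as a pair in this one setting, clearance shows no shift that can be told from the scatter, and the comparison is free of any other structural difference: the fact that compounds 2 and 3 differ only in the configuration as drawn.

As far as these compounds go, the pair does not separate the two stereocentres, so the effect of inverting either one alone remains open. Also unknown is whether the same inversion would stay within the scatter in compounds carrying an amine or a carboxylic acid.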